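A few compounds are considered here, and "the series" means these few. Any claim that something is new, unique, unknown or untested is made for them only; others in the source may bear on it.

Measured so far in a functional assay on the whole organism (Tail, strain ICR) with Mus musculus as the target, in the tail flick test, with a stated time of 90 min, at a dose of 25 umol/kg by the oral route; on this read-out lower numbers stand for a weaker effect and higher numbers for a stronger effect at the one dose given:
- compound 1, `N=C(N)NCCC[C@H](NC(=O)CN(c1nc(Cl)nc2[nH]cnc12)C1CC1)C(=O)O`: 27.6%
- compound 2, `CC[C@H](C)[C@H](NC(=O)CN(c1nc(Cl)nc2[nH]cnc12)C1CC1)C(=O)O`: 27.4%

Compound 2 has the lower of the two numbers, but compound 1 lies within the scatter of it, so the two values show no difference. The next compound, compound 3, is `CC[C@H](C)[C@H](NC(=O)CN(c1nc(Cl)nc2[nH]cnc12)C1CC1)C(=O)OCc1ccccc1`; the change from compound 2 is benzyl in place of hydrogen on an oxygen next to a carbonyl group. For the measured compounds named here, the one measured step, a number 0.2 percentage points lower from compound 1 to compound 2 (within the scatter), sits on the saturated chain carbon and not on the oxygen of the carbonyl group, so no measured step bears on this change. Without any precedent, the step from compound 2 to compound 3 is expected to be a number 0.4 percentage points lower from compound 2 to compound 3 (within the scatter), that is, none beyond the scatter. Compound 3 is therefore estimated at 27%, in the range 8% to 50%.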

Compound 3, a percentage reported as activity, at one dose (the size of the read-out at that dose, not a potency): 36.3%
Compound 3: the middle estimate sits 9.3 percentage points below what was measured, and the stated range covers the measured number.
By their numbers in this assay, from the lowest: compounds 2, 1 and 3 (each within the scatter of the next).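

For the compounds shown here, on the oxygen next to a carbonyl group, the change from carboxy to benzyloxycarbonyl gives the first measured step at this position in this assay (a number 8.9 percentage points higher from compound 2 to compound 3 (within the scatter)). For this pair, the oxygen carries benzyl in place of hydrogen with no difference beyond the scatter, so the free carboxy is not needed to keep this read-out at the one dose given. No evidence is available to explain this result.

Going by these compounds, whether methyl or ethyl on this oxygen would read the same stays open, as does a primary amide in place of the carboxy. On these data alone, it is also open whether benzyl on the same oxygen of compound 1 would behave as it does here.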